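The source may report more compounds than this note shows. Statements on the series, on what has been measured and on what is new or still open speak of the compounds shown alone.

Working notes on the series. In a functional assay on FM3A cells (Mus musculus) for antiproliferative activity (on this read-out higher numbers stand for weaker inhibition and lower numbers for stronger inhibition), compound 2 `COc1cc(C(=O)c2sc(-c3ccc(Cl)cc3)cc2N)cc(OC)c1OC` gives 90 nM, and compound 3 `COc1cc(C(=O)c2sc(-c3cccc([N+](=O)[O-])c3)cc2N)cc(OC)c1OC` gives 17 nM, which leaves compound 2 with the higher of these two numbers. Compound 1 `COc1cc(C(=O)c2sc(-c3ccc(-c4ccccc4)cc3)cc2N)cc(OC)c1OC` reports only a limit, > 10000 nM.

Compound 4 `COc1cc(C(=O)c2sc(-c3ccncc3)cc2N)cc(OC)c1OC` is not yet measured. It carries pyridin-4-yl in place of 4-chlorophenyl on an aromatic carbon, next to the ring sulfur: pyridin-4-yl in place of 4-chlorophenyl on an aromatic carbon.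

For the measured compounds named here, two measured steps bear on this change. The closest is a 5.3-fold lower number from compound 2 to compound 3 (0.72 log units; beyond the scatter), which also replaces the 4-chlorophenyl, here with 3-nitrophenyl. The other is an at least 110-fold lower number from compound 1 to compound 2 (2.04 log units; beyond the scatter), a large step with chloro in place of phenyl on an aromatic carbon. Together they show that this assay responds strongly to the group at this place, but neither step puts a ring nitrogen there, so the direction remains uncertain.

The expected change is modest and leans towards weaker inhibition: a 2.2-fold higher number from compound 2 to compound 4 (0.35 log units; beyond the scatter). For compound 4 the estimated value is 200 nM, with an expected range of 40 nM to 1000 nM.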

Compound 4, half-maximal inhibitory concentration: 150 nM
Beside the measured number, compound 4's estimate is 1.3-fold (0.12 log units) above it, and the stated range covers the measured number.
By their numbers in this assay, from the lowest: compound 3; then compounds 2 and 4 (each within the scatter of the next). At a limit, above all of these: compound 1.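

In this assay, putting a ring nitrogen at this place, with pyridin-4-yl as the ring, leaves the number within the scatter of the 4-chlorophenyl compound: a 1.7-fold higher number from compound 2 to compound 4 (0.22 log units; within the scatter). The same exchange set against 3-nitrophenyl gives a clear difference, an 8.8-fold higher number from compound 3 to compound 4 (0.95 log units; beyond the scatter), so of the three compounds with a single ring here, compound 3 alone stands apart from the other two. The set therefore shows that this place accepts a six-membered aromatic ring with a hetero atom as well as one of carbon only, though no measured property among the data bears on why.

From the compounds shown here alone, it remains open whether the edge of compound 3 follows the nitro group or its place on the ring, which 3-chlorophenyl and 4-nitrophenyl would separate. How pyridin-3-yl or 4-aminophenyl would read at this place is also unknown.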